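Isopropyl on the glycine carbon of a piperazine amide

A few compounds are considered here, and "the series" means these few. Any claim that something is new, unique, unknown or untested is made for them only; others in the source may bear on it.

Compound 2 `CNCC(=O)N1CCN(CCCOc2ccc(C(=O)C3CC3)cc2)CC1`: 79400 nM
Compound 1 `CCCCCC(=O)c1ccc(OCCCN2CCN(C(=O)[C@@H](CC(C)C)NC(=O)OC(C)(C)C)CC2)cc1`: 4470 nM

In an assay for binding affinity to histamine H2 receptor (Homo sapiens) (on this read-out lower numbers stand for stronger inhibition and higher numbers for weaker inhibition), compound 2 gives the higher of the two numbers measured, and compound 1 gives the lower one. Compound 3 `CN[C@@H](C(=O)N1CCN(CCCOc2ccc(C(=O)C3CC3)cc2)CC1)C(C)C` differs from compound 2 by one change: isopropyl in place of hydrogen on a saturated chain carbon bound to an amine nitrogen and a carbonyl carbon. For the measured compounds named here, no measured pair isolates this change, so the expectation rests on compound 2 alone with compound 1 as a distant point of reference. The step from compound 2 to compound 3 is expected to lower the number in this assay by a modest margin, a 2.6-fold lower number from compound 2 to compound 3 (0.42 log units; beyond the scatter), beyond the scatter but well short of the gap to compound 1. Compound 3 is therefore estimated at 30000 nM, with a range from 8000 nM to 100000 nM.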

Compound 3, inhibition constant: 49000 nM
The estimate for compound 3 lay 1.6-fold (0.21 log units) below the measured number; measured number inside the range.
By their numbers in this assay, from the lowest: compound 1; then compounds 3 and 2 (each within the scatter of the next).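

In this assay, isopropyl in place of hydrogen on a saturated chain carbon bound to an amine nitrogen and a carbonyl carbon gives a 1.6-fold lower number from compound 2 to compound 3 (0.21 log units; within the scatter), so at this position the added three carbons leave no change that can be told from the scatter. No supporting measurement bears on this result. Going by these compounds, whether a benzyl group or a carboxylic acid at this carbon would move the number beyond the scatter remains open. So does whether the opposite configuration at this carbon would read the same.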